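The source may report more compounds than this note shows. Statements on the series, on what has been measured and on what is new or still open speak of the compounds shown alone.

Measured in a functional assay on OVCAR-5 cells (Homo sapiens) for inhibition, read by sulforhodamine B assay, with a stated time of 48 h; a lower number here means that less compound is tolerated, a higher number that more compound is tolerated:
compound 1 `COc1ccc(-c2cc(/C=C/C(=O)c3ccc(N)cc3)[nH]n2)cc1` gives 16000 nM
compound 2 `COc1ccc(-c2cc(/C=C/C(=O)c3ccc(N)cc3)[nH]n2)cc1OC` gives 36300 nM
compound 3 `COc1cc(C(=O)/C=C/c2cc(-c3cc(OC)c(OC)c(OC)c3)n[nH]2)cc(OC)c1OC` gives 5920 nM

Compound 3 has the lowest number of the three; compound 1 comes nearest and compound 2 furthest, both gaps beyond the scatter. The difference between the core of compound 3 and the core of compound 2 is not broken down here. Between compound 2 and compound 1 the change is hydrogen in place of methoxy on an aromatic carbon, and in this assay it gave a 2.3-fold lower number from compound 2 to compound 1 (0.36 log units; beyond the scatter).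

Compound 4 `COc1ccc(-c2cc(/C=C/C(=O)c3cc(OC)c(OC)c(OC)c3)[nH]n2)cc1OC` is not yet measured. From compound 3 it is reached by hydrogen in place of methoxy on an aromatic carbon. This is the same kind of change as from compound 2 to compound 1, not the same: the place in compound 4 is also meta to a methoxy group, which the place in compound 2 is not. The change occurs twice among these compounds, once measured. The expectation for compound 4 rests on that single step, because a 2.3-fold lower number from compound 2 to compound 1 (0.36 log units; beyond the scatter) was a modest lowering; a step of similar size is expected, a 2.1-fold lower number from compound 3 to compound 4 (0.33 log units; beyond the scatter). Compound 4 is estimated at 2800 nM, expected between 1200 nM and 7000 nM.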

Compound 4, concentration lethal to 50% of the cells: 13700 nM
Compound 4: the middle estimate sits 4.9-fold (0.69 log units) below what was measured; the measured number lies above the stated range.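

In this assay, hydrogen in place of methoxy on an aromatic carbon gave a 2.3-fold higher number from compound 3 to compound 4 (0.36 log units; beyond the scatter), so the direction of this change did not carry over from one core to the other. The two steps stand apart by more than their combined scatter: the same change on two cores in this assay, a 2.3-fold lower number (0.36 log units; beyond the scatter) from compound 2 to compound 1 and a 2.3-fold higher number (0.36 log units; beyond the scatter) from compound 3 to compound 4, 5.3-fold (0.72 log units) apart, beyond the scatter of two such steps

Among these compounds, this shows that, within this series, the step measured on one core is a poor guide to the step on the other, but with only one measured step per core it does not show why they differ, since the two steps differ both in the rest of the core and in the surroundings of the place changed.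

The compounds shown leave open how a hydroxyl group, a chlorine atom or a longer alkoxy chain would read in place of that methoxy on either core. Also open, on these data alone, is whether a further core would follow the lowering or the rise, and so whether either direction is the more typical one.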